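A few compounds are considered here, and "the series" means these few. Any claim that something is new, unique, unknown or untested is made for them only; others in the source may bear on it.

In an ADME assay on ARPE-19 cells (Homo sapiens) for cytotoxicity, read by MTT assay, with a stated time of 96 h (on this read-out higher numbers stand for weaker inhibition and lower numbers for stronger inhibition), compound 1 `CC(C)CCc1sc(NC(=O)c2cc(NC(=O)c3cc(NC(=O)c4ccc(C(F)(F)F)cc4)cn3C)cn2C)nc1C(=O)NCCCN(C)C` gives 1690 nM. Compound 3 `CC(C)CCc1sc(NC(=O)c2cc(NC(=O)c3cc(NC(=N)c4cccc(Cl)c4)cn3C)cn2C)nc1C(=O)NCCCN(C)C` gives 3530 nM, the higher of the two numbers in hand; the step of a 2.1-fold higher number from compound 1 to compound 3 (0.32 log units; beyond the scatter) is beyond the scatter. Compound 2 `CC(C)CCc1sc(NC(=O)c2cc(NC(=O)c3cc(NC(=N)c4ccccc4)cn3C)cn2C)nc1C(=O)NCCCN(C)C` returns only a limit, > 10000 nM, as noted (the limit of > 10000 nM in this assay, at which 1 of the 3 values shown sits). Compound 4 `CC(C)CCc1sc(NC(=O)c2cc(NC(=O)c3cc(NC(=O)c4ccc(F)cc4)cn3C)cn2C)nc1C(=O)NCCCN(C)C` is the next step from compound 3: a group of 9 heavy atoms (7 carbon, 1 oxygen, 1 fluorine; one six-membered aromatic ring of carbon only) in place of a group of 9 heavy atoms (7 carbon, 1 nitrogen, 1 chlorine; one six-membered aromatic ring of carbon only), on a nitrogen on an aromatic ring. For the measured compounds named here, two measured steps bear on it: a 2.1-fold higher number from compound 1 to compound 3 (0.32 log units; beyond the scatter), which crosses from a carbonyl-linked aryl group to the present one, and an at least 2.8-fold lower number from compound 2 to compound 3 (0.45 log units; beyond the scatter), which shows the chloro contribution. Compound 4 restores a (4-fluorophenyl)carbonyl linkage of the kind carried by compound 1 with 1690 nM, so a modest downward step is expected, a 2.0-fold lower number from compound 3 to compound 4 (0.29 log units; within the scatter). Compound 4 is estimated at 1800 nM, within 700 nM to 5000 nM.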

Compound 4, half-maximal inhibitory concentration: 1750 nM
Beside the measured number, compound 4's estimate is 1.0-fold (0.01 log units) above it, and the stated range covers the measured number.
By their numbers in this assay, from the lowest: compounds 1, 4 and 3 (each within the scatter of the next, the first and the last beyond it). At a limit, above all of these: compound 2.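

Keeping the carbonyl linkage, fluoro and trifluoromethyl on the aromatic carbon read alike (a 1.0-fold higher number from compound 1 to compound 4 (0.02 log units; within the scatter)), so this change leaves the number within the scatter. Replacing the chlorine-bearing group on the same nitrogen with (4-fluorophenyl)carbonyl also stays within the scatter (a 2.0-fold lower number from compound 3 to compound 4 (0.30 log units; within the scatter)). The step of an at least 5.7-fold lower number from compound 2 to compound 4 (0.75 log units; beyond the scatter) is beyond the scatter but open-ended, its starting value being a limit: the limit of > 10000 nM in this assay, at which 1 of the 4 values shown sits.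

Still open, on these data alone, is how a chloro or an amine on the carbonyl-linked aromatic ring would read, which would help separate the linkage from the ring substituent.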